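This account rests on a few compounds, and the source may have more. Where it says the series, first, only, none or still open, it means among the compounds named here.

Compound 1 `CC1=CC[C@H](C(C)(C)NC(=S)N/N=C/c2ccc(O)cc2)CC1` is the reference point of this small set. In a functional assay on NCI-H460 cells (Homo sapiens) for inhibition, read by sulforhodamine B assay, with a stated time of 48 h (a lower number here means a stronger inhibitor of growth, a higher number a weaker inhibitor of growth), compound 1 gives > 100000 nM, which is a limit of the assay and not a number. Compound 2 `CC1=CC[C@H](C(C)(C)NC(=S)N/N=C/c2ccc(N(C)C)cc2)CC1` carries dimethylamino in place of hydroxy on an aromatic carbon; in this assay compound 2 gives > 100000 nM, again a limit. Compound 3 `COc1cc(/C=N/NC(=S)NC(C)(C)[C@H]2CC=C(C)CC2)ccc1O` carries methoxy in place of hydrogen on an aromatic carbon; in this assay compound 3 gives > 100000 nM, also a limit. Both measured steps, a step that the two limits leave unreadable from compound 1 to compound 2 and a step that the two limits leave unreadable from compound 1 to compound 3, are of unreadable size, since every value shown sits at the limit of > 100000 nM in this assay, at which 3 of the 3 values shown sit. Compound 1 thus stands at the limit with no number of its own.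

Compound 4 `CC1=CC[C@H](C(C)(C)NC(=S)N/N=C/c2ccco2)CC1` differs from compound 1 by furan-2-yl in place of 4-hydroxyphenyl on a carbon with a double bond to nitrogen. Going by the values given here, no measured step covers this change, and the two measured steps, both unreadable, give neither a size nor a direction to carry over. For compound 4 in this assay the value is expected to remain at the limit, estimated as 100000 nM with a range from 30000 nM to 300000 nM. The step this estimate implies, a number no higher from compound 1 to compound 4 (the limit leaves the size open), is expected to be none beyond the scatter, with the size itself most likely unreadable.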

Compound 4, concentration for total growth inhibition: 10800 nM
Compound 4: middle estimate off by 9.3-fold (0.97 log units), on the high side; measured number outside the range, below it.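

In this assay, furan-2-yl in place of 4-hydroxyphenyl on a carbon with a double bond to nitrogen gives an at least 9.2-fold lower number from compound 1 to compound 4 (0.96 log units; beyond the scatter), so a change at this place can bring a compound of the series off the limit, which the two earlier steps, neither of which can be read, could not show. The size of this step is open at its upper end, since compound 1 has only a limit and no number of its own. The change replaces the whole aromatic group, and compound 4 is the only compound in the set with a measured number, the others remaining at the limit: the limit of > 100000 nM in this assay, at which 3 of the 4 values shown sit.

The compounds shown do not separate the contribution of the five-membered ring from that of removing the hydroxy group, and a single change cannot show whether the gain extends to other groups. Unsubstituted phenyl, thiophen-2-yl and pyridin-2-yl on the same carbon would address this, and whether a methyl or bromo group on the furan ring keeps the number in this assay also remains open.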